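Working notes: the step from compound 3 to compound 4

The source may hold more compounds than are shown below. What is called first, only, known or untested is meant among the compounds shown, and "the series" means these compounds.

Measured so far in an assay on isolated protein for displacement of a labelled ligand from Apoptosis regulator Bcl-2 (Homo sapiens), read by fluorescence polarization; on this read-out lower numbers stand for stronger inhibition and higher numbers for weaker inhibition:
- Compound 1, `CN(C)CC[C@H](CSc1ccccc1)Nc1ccc(S(=O)(=O)NC(=O)c2ccc(N3CCN(Cc4ccccc4)CC3)cc2)cc1[N+](=O)[O-]`, gives 39.8 nM.
- Compound 2, `CN(C)CC[C@H](CSc1ccccc1)Nc1ccc(S(=O)(=O)NC(=O)c2ccc(N3CCN(Cc4ccccc4C(F)(F)F)CC3)cc2)cc1[N+](=O)[O-]`, gives < 1 nM; this is a limit of the assay, not a number.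
- Compound 3, `CN(C)CC[C@H](CSc1ccccc1)Nc1ccc(S(=O)(=O)NC(=O)c2ccc(N3CCN(Cc4ccccc4-c4cccnc4)CC3)cc2)cc1[N+](=O)[O-]`, gives 1 nM.

Compound 3 holds the lowest of the two numbers; its nearest neighbour is compound 1, and the step reads a 40-fold lower number from compound 1 to compound 3 (1.60 log units; beyond the scatter). The second large step in the set is an at least 39-fold lower number from compound 1 to compound 2 (1.59 log units; beyond the scatter). For compound 2 only a limit is known (the limit of < 1 nM in this assay, at which 1 of the 3 values shown sits), so the comparison a number no lower from compound 2 to compound 3 (the limit leaves the size open) cannot be sized.

Compound 4, `COc1ccc(-c2ccccc2CN2CCN(c3ccc(C(=O)NS(=O)(=O)c4ccc(N[C@H](CCN(C)C)CSc5ccccc5)c([N+](=O)[O-])c4)cc3)CC2)cc1`, differs from compound 3 by 4-methoxyphenyl in place of pyridin-3-yl on an aromatic carbon. Among the compounds with values here, both measured large steps replace hydrogen with a group at this carbon; no measured step exchanges one such group for another except the unreadable one from compound 2 to compound 3. The change is therefore expected to give no step beyond the scatter, a 1.5-fold higher number from compound 3 to compound 4 (0.18 log units; within the scatter). Compound 4 is estimated at 1.5 nM in this assay, within a range of 0.5 nM to 5 nM.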

Compound 4, inhibition constant: < 1 nM
Compound 4: no number, only a limit; the forecaster's own chance of this, stated with the estimate: 30%; at least 1.5-fold (0.17 log units) between middle value and limit.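

Compound 4 gives < 1 nM in this assay, which is a limit of the assay and not a number. Set against pyridin-3-yl, the change reads a number no higher from compound 3 to compound 4 (the limit leaves the size open). The 4-methoxyphenyl group on this aromatic carbon, ortho to a large group, gives an at least 39-fold lower number from compound 1 to compound 4 (1.59 log units; beyond the scatter), so the large drop from hydrogen now holds for three groups, and a six-membered aromatic ring of carbon only serves as well as pyridin-3-yl. The step to compound 4 from compound 2 cannot be read, because the read-out stops at a limit: the limit of < 1 nM in this assay, at which 2 of the 4 values shown sit.

On these data alone, how trifluoromethyl, pyridin-3-yl and 4-methoxyphenyl rank at this carbon stays open. Also open, as far as these compounds go, is whether an amine or a carboxylic acid on the added ring, or a small group such as methyl or fluorine on this carbon, would keep the numbers this low.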